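Adding Chloro to an Aromatic Carbon of Compound 1

A few compounds are considered here, and "the series" means these few. Any claim that something is new, unique, unknown or untested is made for them only; others in the source may bear on it.

Compound 1 `COC(=O)[C@@]1(C)CCC=C2[C@@H]1CC[C@@H](C)[C@]2(C)Cc1c(C)[nH]c2ccccc12` gives 19000 nM in a functional assay on WiDr cells (Homo sapiens) for inhibition, read by sulforhodamine B assay, with a stated time of 48 h; on this read-out lower numbers stand for stronger inhibition of growth and higher numbers for weaker inhibition of growth.
Compound 2 `COC(=O)[C@@]1(C)CCC=C2[C@@H]1CC[C@@H](C)[C@]2(C)Cc1c(C)[nH]c2ccc(F)cc12` gives 17000 nM in this assay.
Compound 3 `COC(=O)[C@@]1(C)CCC=C2[C@@H]1CC[C@@H](C)[C@]2(C)Cc1c(C)[nH]c2ccc(OC)cc12` gives 17000 nM in this assay.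

The three measured numbers for compound 1, compound 2 and compound 3 all lie within the scatter of one another, so none of them can be called stronger or weaker. Compound 4 `COC(=O)[C@@]1(C)CCC=C2[C@@H]1CC[C@@H](C)[C@]2(C)Cc1c(C)[nH]c2c(Cl)cccc12` has not yet been measured; it differs from compound 1 by chloro in place of hydrogen on an aromatic carbon. Going by the values given here, two measured steps bear on this change: a 1.1-fold lower number from compound 1 to compound 2 (0.05 log units; within the scatter) and a 1.1-fold lower number from compound 1 to compound 3 (0.05 log units; within the scatter). Each of those also placed a small group on an aromatic carbon of the same ring, and neither moved the number beyond the scatter. The chloro of compound 4 sits on a different carbon, ortho to a fused ring, so those steps are only a rough guide; still, no change beyond the scatter is expected, a 1.1-fold lower number from compound 1 to compound 4 (0.02 log units; within the scatter). For compound 4 a value of 18000 nM is estimated, with a range from 9000 nM to 36000 nM.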

Compound 4, concentration for 50% growth inhibition: 29000 nM
The estimate for compound 4 lay 1.6-fold (0.21 log units) below the measured number; the measured number falls inside the stated range.
By their numbers in this assay, from the lowest: compounds 2, 3, 1 and 4 (each within the scatter of the next).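

Chloro on this aromatic carbon, ortho to a fused ring, gives a 1.5-fold higher number from compound 1 to compound 4 (0.18 log units; within the scatter) in this assay and so stays within the scatter. Going by these compounds alone, a second carbon of this six-membered aromatic ring, different from the one carrying fluoro in compound 2 and methoxy in compound 3, has therefore taken a small group without a clear change. Nothing available offers a reason for this result.

Going by these compounds, whether an amine, a carboxylic acid or a longer chain on this carbon would also stay within the scatter of compound 1 remains open. So does whether fluoro or methoxy here would match chloro.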